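The compounds below may be only part of what the source reports. "The series", "measured", "known", "first", "only" and "open" are said of these compounds alone.

Compound 1, with the structure `COc1ccc(C(=O)/C=C/c2ccc3c(ccc[n+]3[O-])c2)cc1`, and compound 3, with the structure `O=C(/C=C/c1ccc2c(ccc[n+]2[O-])c1)c1ccc(Cl)cc1`, share one core and differ in a single place: chloro in place of methoxy on an aromatic carbon. In a functional assay on HL-60 cells (Homo sapiens) for antiproliferative activity, read by MTT assay, with a stated time of 48 h (a higher number here means a weaker inhibitor, a lower number a stronger inhibitor), compound 1 gives 14.8 ug/mL, while compound 3 gives 33.8 ug/mL, so that the change produced a 2.3-fold higher number from compound 1 to compound 3 (0.36 log units; beyond the scatter). Compound 2, with the structure `COc1ccc(C(=O)/C=C/c2ccc3ncccc3c2)cc1`, is built on a second core; how its core differs from that of compound 1 is not broken down here. In this assay compound 2 gives 12.6 ug/mL, a figure that lies within the scatter of the value of compound 1, so no order between these two can be claimed, whereas compound 3 stands beyond the scatter from both.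

Compound 4, with the structure `O=C(/C=C/c1ccc2ncccc2c1)c1ccc(Cl)cc1`, has not yet been measured. It stands to compound 2 as compound 3 stands to compound 1: chloro in place of methoxy on an aromatic carbon. The place of the change is the same word for word in both pairs, so this is the same change made on the second core. Among the measured compounds shown here, for compound 4 in this assay the expectation is a 2.3-fold higher number from compound 2 to compound 4 (0.36 log units; beyond the scatter), resting on the only precedent, the step of the same change seen as a 2.3-fold higher number from compound 1 to compound 3 (0.36 log units; beyond the scatter), and on the value of compound 2, which is 12.6 ug/mL. On that basis compound 4 is estimated to give 29 ug/mL in this assay, with a range from 15 ug/mL to 56 ug/mL.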

Compound 4, half-maximal inhibitory concentration: 8.8 ug/mL
Compound 4: middle estimate off by 3.3-fold (0.52 log units), on the high side, and the stated range ends above it.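

In this assay the replacement of methoxy by chloro on the aromatic carbon did not carry over unchanged from one core to the other, and the two steps differ: the same change on two cores in this assay, a 2.3-fold higher number (0.36 log units; beyond the scatter) from compound 1 to compound 3 and a 1.4-fold lower number (0.16 log units; within the scatter) from compound 2 to compound 4, 3.3-fold (0.51 log units) apart, beyond the scatter of two such steps.

On the second core the step (a 1.4-fold lower number from compound 2 to compound 4 (0.16 log units; within the scatter)) stays within the scatter, so compound 2 and compound 4 cannot be put in order, whereas on the first core the same replacement clearly separates compound 1 and compound 3. Among the compounds shown here, this does not show a reversal of direction on the second core, as the lower number for compound 4 cannot be told from scatter, and with only one pair on each core it gives no reason why the cores part ways.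

The compounds shown leave open whether other groups on that aromatic carbon, such as fluoro, a nitrile, an amine or a carboxylic acid, would also depend on the core in this way. They also leave open how the exchange of methoxy for chloro would behave on any further core, and whether the gap between the two steps would recur in another assay.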